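The compounds below may be only part of what the source reports. "The series", "measured", "known", "first", "only" and "open" are said of these compounds alone.

Going by the values given here, in a functional assay on NCI-H460 cells (Homo sapiens) for inhibition, read by CCK-8 assay, with a stated time of 4 days (a higher number here means a weaker inhibitor, a lower number a stronger inhibitor), compound 1 `COc1cc(C(=O)O)ccc1NC(=O)[C@@H]1N[C@@H](CC(C)(C)C)[C@](C)(c2ccc(Cl)cc2F)[C@H]1c1cccc(Cl)c1F` gives 270 nM and compound 2 `COc1cc(C(=O)O)ccc1NC(=O)[C@@H]1N[C@@H](CC(C)(C)C)[C@](CNCc2ccccn2)(c2ccc(Cl)cc2F)[C@H]1c1cccc(Cl)c1F` gives 470 nM, so compound 2 stands within the scatter of the only other measured compound. Compound 3 `COc1cc(C(=O)O)ccc1NC(=O)[C@@H]1N[C@@H](CC(C)(C)C)[C@](CNCc2cccnc2)(c2ccc(Cl)cc2F)[C@H]1c1cccc(Cl)c1F` carries pyridin-3-yl in place of pyridin-2-yl on a saturated chain carbon bound to an amine nitrogen. Among the compounds with values here, no measured step tests this swap directly. The nearest evidence is a 1.7-fold higher number from compound 1 to compound 2 (0.24 log units; within the scatter), which brought in the whole ((pyridin-2-yl)methyl)amino group, so no change beyond the scatter is expected in this assay. The expected step is a 1.1-fold lower number from compound 2 to compound 3 (0.05 log units; within the scatter). For compound 3 the estimate is 420 nM, with an expected range of 180 nM to 950 nM.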

Compound 3, half-maximal inhibitory concentration: 700 nM
For compound 3 the middle estimate is 1.7-fold (0.22 log units) below the measured one, and the stated range covers the measured number.
By their numbers in this assay, from the lowest: compounds 1, 2 and 3 (each within the scatter of the next, the first and the last beyond it).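

Putting pyridin-3-yl in place of pyridin-2-yl on a saturated chain carbon bound to an amine nitrogen gives a 1.5-fold higher number from compound 2 to compound 3 (0.17 log units; within the scatter) in this assay, so the two pyridine attachments cannot be told apart here. Set against hydrogen, the ((pyridin-3-yl)methyl)amino group gives a 2.6-fold higher number from compound 1 to compound 3 (0.41 log units; beyond the scatter), the only step shown at this position that passes the scatter, and a modest one. No measurement shown offers an explanation for either step. The compounds shown leave open how pyridin-4-yl or phenyl would read in this place, and whether a morpholine or an amide in place of the amine would shift the number.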